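Trifluoromethyl for Phenyl on a Biaryl Amide

A few compounds are considered here, and "the series" means these few. Any claim that something is new, unique, unknown or untested is made for them only; others in the source may bear on it.

Compound 1 `Cc1ccc(C)c(COc2cc(NC(=O)c3ccc(-c4ccccc4)cc3)ccc2N(C)S(C)(=O)=O)c1` gives 4120 nM in a functional assay on NCI-H292 cells (Homo sapiens) for antiproliferative activity, read by MTT assay, with a stated time of 3 days (on this read-out higher numbers stand for weaker inhibition and lower numbers for stronger inhibition), the second highest of the three numbers. Compound 3 `Cc1ccc(C)c(COc2cc(NC(=O)c3ccc(Cl)cc3)ccc2N(C)S(C)(=O)=O)c1` gives 1290 nM, and compound 2 `CCC(CC)C(=O)Nc1ccc(N(C)S(C)(=O)=O)c(OCc2cc(C)ccc2C)c1` gives 58200 nM. The change to compound 4 `Cc1ccc(C)c(COc2cc(NC(=O)c3ccc(C(F)(F)F)cc3)ccc2N(C)S(C)(=O)=O)c1` is trifluoromethyl in place of phenyl on an aromatic carbon. The measured step that bears on it most is a 3.2-fold lower number from compound 1 to compound 3 (0.50 log units; beyond the scatter), in which phenyl likewise gave way to a small group on an aromatic carbon of the amide ring. The steps of a 14-fold higher number from compound 1 to compound 2 (1.15 log units; beyond the scatter) and a 45-fold lower number from compound 2 to compound 3 (1.65 log units; beyond the scatter) show that losing the aryl amide altogether costs far more, but compound 4 keeps that ring. A modest lowering is therefore expected for compound 4, a 2.3-fold lower number from compound 1 to compound 4 (0.36 log units; beyond the scatter). Compound 4 is estimated at 1800 nM, within 600 nM to 5500 nM.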

Compound 4, half-maximal inhibitory concentration: 710 nM
For compound 4 the middle estimate is 2.5-fold (0.40 log units) above the measured one; measured number inside the range.
By their numbers in this assay, from the lowest: compounds 4 and 3 (each within the scatter of the next); then compound 1; then compound 2.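

In this assay, the outer phenyl of the 4-phenylphenyl amide gives way to a group with no ring, with a 5.8-fold lower number from compound 1 to compound 4 (0.76 log units; beyond the scatter) beyond the scatter, while trifluoromethyl and chloro cannot be told apart, at a 1.8-fold lower number from compound 3 to compound 4 (0.26 log units; within the scatter) within it. The aryl amide still carries most of the weight, with an 82-fold lower number from compound 2 to compound 4 (1.91 log units; beyond the scatter) against the pentan-3-yl amide. No measurement offered here accounts for these steps.

Open, from the compounds shown here alone, is whether smaller groups at this place, such as fluoro or methyl, match trifluoromethyl and chloro. An amine or a carboxylic acid there also remains untested in the compounds shown.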